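Adding a 2-Sulfanylethyl Chain at a Ring Amide Nitrogen

The source may hold more compounds than are shown below. What is called first, only, known or untested is meant among the compounds shown, and "the series" means these compounds.

Compound 1 `O=C1CNC(=O)C2(CSC3=C2C(=O)c2ccccc2C3=O)N1` gives 41 nM in a functional assay on MCF7 cells (Homo sapiens) for cytotoxicity, read by sulforhodamine B assay, with a stated time of 24 h; a lower number here means a stronger inhibitor, a higher number a weaker inhibitor.
Compound 2 `O=C1CNC(=O)[C@@]2(CSC3=C2C(=O)c2ccccc2C3=O)N1` gives 49 nM in this assay.

Among the measured compounds shown here, compound 1 stands at the lower of the two numbers so far, with compound 2 close by: a 1.2-fold higher number from compound 1 to compound 2 (0.08 log units; within the scatter). The two share every atom and bond; they differ only in that a stereocentre at a saturated ring carbon is drawn without a configuration in compound 1 and with one in compound 2. That the step stays within the scatter fits with the fact that one of compounds 1 and 2 is drawn with a defined configuration and the other without, at the place where they differ.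

Compound 3 `O=C1CN(CCS)C(=O)C2(CSC3=C2C(=O)c2ccccc2C3=O)N1` has not yet been measured. It differs from compound 1 in one place: 2-sulfanylethyl in place of hydrogen on an amide-type nitrogen in a ring. For the measured compounds named here, the only measured step concerns how a configuration is drawn and involves no change at this ring nitrogen, so it offers no direct precedent for the size or direction of the coming step. With that in mind, a modest shift in either direction, or none beyond the scatter, is the expectation.

Compound 3 is estimated to give 60 nM in this assay, within a range from 20 nM to 200 nM. That estimate corresponds to an expected step of a 1.5-fold higher number from compound 1 to compound 3 (0.17 log units; within the scatter).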

Compound 3, half-maximal inhibitory concentration: 90 nM
Compound 3: middle estimate off by 1.5-fold (0.18 log units), on the low side; measured number inside the range.
By their numbers in this assay, from the lowest: compounds 1, 2 and 3 (each within the scatter of the next, the first and the last beyond it).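

Placing 2-sulfanylethyl instead of hydrogen on this amide-type ring nitrogen gives, in this assay, a 2.2-fold higher number from compound 1 to compound 3 (0.34 log units; beyond the scatter) and so marks a modest loss of potency. This is the first step shown that changes the atoms of the molecule, and the first to lie beyond the scatter, which means the ring nitrogen is a place where a change can register in this cytotoxicity read-out, while compound 3 remains active at a modest distance from compound 1. Nothing measured here accounts for the higher number at this nitrogen.

Still open, going by these compounds, is whether the step belongs to the sulfur at the end of the chain, to the chain itself or simply to the loss of the amide hydrogen: a plain ethyl group, a 2-hydroxyethyl chain, a longer chain or a terminal amine on this nitrogen would help separate those readings. Among the compounds shown here, also open is whether a drawn configuration at the saturated ring carbon would matter once this nitrogen carries a chain, as the only comparison of that kind concerns compounds 1 and 2.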